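A few compounds are considered here, and "the series" means these few. Any claim that something is new, unique, unknown or untested is made for them only; others in the source may bear on it.

Measured so far:
compound 1 `COc1ccc(CNc2nc(SC)nc3ncccc23)cc1`: 58500 nM
compound 2 `CSc1nc(NCc2ccccc2)c2cccnc2n1`: 25900 nM

In an ADME assay on BEAS-2B cells (Homo sapiens) for cytotoxicity, read by MTT assay, with a stated time of 72 h (on this read-out higher numbers stand for weaker inhibition of growth and lower numbers for stronger inhibition of growth), compound 2 gives 25900 nM, the lowest of the two numbers, while compound 1 gives 58500 nM. Going by the values given here, the single measured step, a 2.3-fold lower number from compound 1 to compound 2 (0.35 log units; beyond the scatter), changes only a substituent on the aromatic ring and leaves the ring in place. Compound 3 `CSc1nc(NCCCCCO)c2cccnc2n1` differs from compound 2 by 4-hydroxybutyl in place of phenyl on a saturated chain carbon bound to a nitrogen on an aromatic ring. Among the compounds with values here, no measured step touches this kind of change, so the expectation rests on compound 2 alone and is wide. For compound 3 the expected step is a 1.5-fold higher number from compound 2 to compound 3 (0.19 log units; within the scatter). Compound 3 is estimated at 40000 nM, within 15000 nM to 120000 nM.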

Compound 3, concentration for 50% growth inhibition: > 100000 nM
Compound 3: no number, only a limit; the forecaster's own chance of this, stated with the estimate: 15%; middle value at least 2.5-fold (0.39 log units) away from the limit.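

In this assay, 4-hydroxybutyl in place of phenyl gives an at least 3.8-fold higher number from compound 2 to compound 3 (0.58 log units; beyond the scatter), so this position also moves the read-out, towards weaker inhibition of growth, and not only the substituent on the aromatic ring. Compound 3 gives a limit and not a number, so the step has a floor but no known upper end: the limit of > 100000 nM in this assay, at which 1 of the 3 values shown sits.

Going by these compounds, whether the loss of the phenyl ring or the entry of the hydroxyl group drives the step stays open, as compound 3 changes both at once. A plain butyl chain or a terminal amine on the chain would separate the two.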